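A ring swap on a compound at the limit

The source may report more compounds than this note shows. Statements on the series, on what has been measured and on what is new or still open speak of the compounds shown alone.

Values in an ADME assay on RAW264.7 cells (Mus musculus) for cytotoxicity, read by MTT assay; on this read-out lower numbers stand for stronger inhibition and higher numbers for weaker inhibition:
Compound 1 `CCCCCCCCCCOc1cccc(O)c1C(=O)/C=C/c1ccc(O)cc1`: > 30000 nM (a limit)
Compound 2 `CCCCC/C=C\CCCCOc1cccc(O)c1C(=O)/C=C/c1ccc(O)cc1`: > 30000 nM (a limit)
Compound 3 `CCCCCCCCCCOc1cccc(O)c1C(=O)/C=C/c1ccc(O)c(Cl)c1`: > 30000 nM (a limit)

Compound 3 stands at > 30000 nM, which is a limit and not a number. The whole series sits there, as the limit of > 30000 nM in this assay, at which 3 of the 3 values shown sit, shows. Compound 4 `CCCCCCCCCCOc1cccc(O)c1C(=O)/C=C/c1cc(OC)c(O)c(OC)c1` differs from compound 3 in one place: 4-hydroxy-3,5-dimethoxyphenyl in place of 3-chloro-4-hydroxyphenyl on a double-bonded chain carbon bound to a double-bonded chain carbon. The change is 4-hydroxy-3,5-dimethoxyphenyl in place of 3-chloro-4-hydroxyphenyl on a double-bonded chain carbon bound to a double-bonded chain carbon.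

The nearest measured step is a step that the two limits leave unreadable from compound 1 to compound 3, where chloro replaces hydrogen on an aromatic carbon. The other is a step that the two limits leave unreadable from compound 1 to compound 2, a change in the chain. Neither offers a size to carry over, so no readable step and no direction is expected in this assay. Compound 4 is expected to stay at the same limit. The estimated change is a step that the limit leaves unreadable from compound 3 to compound 4. For compound 4 the estimate is 35000 nM, with an expected range of 12000 nM to 90000 nM.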

Compound 4, half-maximal inhibitory concentration: > 30000 nM
Compound 4: a limit, no number; the forecaster's own chance of this, stated with the estimate: 85%; the middle value is on the limit's open side.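

In this assay compound 4 gives > 30000 nM as a limit and not a number, so the steps to it from compound 3 and from compound 1 cannot be read. The compounds shown leave open whether any of these changes shifts the value at all, with the whole series at one limit: the limit of > 30000 nM in this assay, at which 4 of the 4 values shown sit.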